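This account rests on a few compounds, and the source may have more. Where it says the series, first, only, none or still open, it means among the compounds named here.

Series notes, hydroxamic and anilide chain homologues.

Compound 1 `Cc1ccc(-c2noc(CCCCCCC(=O)NO)n2)cc1` carries a hydroxy on the amide-type nitrogen. In a functional assay on A549 cells (Homo sapiens) for antiproliferative activity, read by MTT assay, with a stated time of 72 h (a lower number here means a stronger inhibitor, a higher number a weaker inhibitor), compound 1 gives 5810 nM. Compound 2 `O=C(CCCCCCc1nc(-c2ccc(C(F)(F)F)cc2)no1)NO` differs from compound 1 by a single change, (trifluoromethyl in place of methyl on an aromatic carbon). In this assay compound 2 gives 14000 nM, and the step reads a 2.4-fold higher number from compound 1 to compound 2 (0.38 log units; beyond the scatter).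

Compound 3 `Cc1ccc(-c2noc(CCCCCCC(=O)Nc3ccccc3N)n2)cc1` keeps the core of compound 1 and differs at the amide end: 2-aminophenyl in place of hydroxy on an amide-type nitrogen. In this assay compound 3 gives 9170 nM, and the step is a 1.6-fold higher number from compound 1 to compound 3 (0.20 log units; within the scatter). Against compound 2 the value of compound 3 sits within the usual scatter, so no order is drawn between them.

Compound 4 `Nc1ccccc1NC(=O)CCCCCCc1nc(-c2ccc(C(F)(F)F)cc2)no1`, not yet measured, stands to compound 3 as compound 2 stands to compound 1: trifluoromethyl in place of methyl on an aromatic carbon. The place of the change is the same as in the pair of compound 1 and compound 2, so this is the same change, made on the core of compound 3 instead of the core of compound 1; the two cores differ only as described above. Going by the values given here, the one precedent for this change, the step from compound 1 to compound 2, was modest and beyond the scatter. Two pairs are too few to claim a pattern, but nothing in the series contradicts a similar shift here.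

For compound 4 in this assay the expected step is a 2.2-fold higher number from compound 3 to compound 4 (0.34 log units; beyond the scatter), resting on compound 1 and compound 2 because of a 2.4-fold higher number from compound 1 to compound 2 (0.38 log units; beyond the scatter). The estimate for compound 4 is 20000 nM. The expected range for compound 4 runs from 9000 nM to 45000 nM.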

Compound 4, half-maximal inhibitory concentration: > 100000 nM
Compound 4 gave a limit, no number; the forecaster's own chance of this, stated with the estimate: 10%; middle value at least 5.0-fold (0.69 log units) from the limit.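

Compound 4 in this assay stands at a limit of the assay, not at a number, so the steps that reach it give only a lower bound on size: the limit of > 100000 nM in this assay, at which 1 of the 4 values shown sits. Trifluoromethyl in place of methyl raises the number on both cores, but an at least 10-fold higher number from compound 3 to compound 4 (1.03 log units; beyond the scatter) does not repeat the size of the step on the core of compound 1, and the two steps lie apart beyond the scatter: the same change on two cores in this assay, a 2.4-fold higher number (0.38 log units; beyond the scatter) from compound 1 to compound 2 and an at least 10-fold higher number (1.03 log units; beyond the scatter) from compound 3 to compound 4, at least 4.5-fold (0.65 log units) apart, beyond the scatter of two such steps. The amide-end change also reads differently on the two cores, with an at least 7.1-fold higher number from compound 2 to compound 4 (0.85 log units; beyond the scatter), so the size of neither change carries from one core to the other in this pair of cores, although the true size of the gap and its cause remain unshown: the same change on two cores in this assay, a 1.6-fold higher number (0.20 log units; within the scatter) from compound 1 to compound 3 and an at least 7.1-fold higher number (0.85 log units; beyond the scatter) from compound 2 to compound 4, at least 4.5-fold (0.65 log units) apart, beyond the scatter of two such steps.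

A single pair of cores cannot tell whether this gap is tied to trifluoromethyl itself or would also appear with another group in that place, such as chloro or methoxy. From the compounds shown here alone, it also remains open whether a shorter or longer chain between the shared core and the amide end, or an amide end other than the hydroxy or 2-aminophenyl forms, would keep the two changes as far apart as they stand here.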